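Ester variation on the carbonyl carbon of the shared core

This account rests on a few compounds, and the source may have more. Where it says the series, first, only, none or still open, it means among the compounds named here.

Three compounds of the series have numbers in an assay on membranes from CHO cells for displacement of a labelled ligand from adenosine receptor A1 (Homo sapiens), read by scintillation counting, with a stated time of 60 min, tested at 1 uM; a lower number here means less inhibition, a higher number more inhibition at the concentration tested (going by the name of the read-out):
compound 1, `CCCC(=O)C1=C(C)NC(=O)NC1c1ccoc1`, gives 1%
compound 2, `CCNC(=O)C1=C(C)NC(=O)NC1c1ccoc1`, gives 1%
compound 3, `CC1=C(C(=O)SC(C)C)C(c2ccoc2)NC(=O)N1`, gives 9%

On the numbers shown compound 3 stands at the upper end of the three, but compound 1 and compound 2 both lie within the scatter of it, so no ranking follows from these values. Two measured steps change the group on the carbonyl carbon, the same place that is varied next: a number 8 percentage points higher from compound 1 to compound 3 (within the scatter) and a number 8 percentage points higher from compound 2 to compound 3 (within the scatter). Neither moves the read-out in this assay beyond the scatter, and all three numbers sit near the bottom of the scale.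

Compound 4, `CC1=C(C(=O)OCC2CC2)C(c2ccoc2)NC(=O)N1`, has not yet been measured. (cyclopropylmethoxy in place of isopropylsulfanyl on a carbonyl carbon). Because the two exchanges at this carbon gave a number 8 percentage points higher from compound 1 to compound 3 (within the scatter) and a number 8 percentage points higher from compound 2 to compound 3 (within the scatter), the step to compound 4 is expected to stay within the scatter, with an expected size of a number 3 percentage points lower from compound 3 to compound 4 (within the scatter). In this assay compound 4 is therefore estimated at 6%, with a range from -4% to 17%.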

Compound 4, a percentage reported as inhibition, at one concentration (the size of the read-out at that concentration, not a potency): 29%
Beside the measured number, compound 4's estimate is 23 percentage points below it; measured number above the stated range.
By their numbers in this assay, from the lowest: compounds 1, 2 and 3 (each within the scatter of the next); then compound 4.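

In this assay, the carbonyl carbon now gives steps beyond the scatter, with cyclopropylmethoxy in place of isopropylsulfanyl (a number 20 percentage points higher from compound 3 to compound 4 (beyond the scatter)), in place of ethylamino (a number 28 percentage points higher from compound 2 to compound 4 (beyond the scatter)) and in place of propyl (a number 28 percentage points higher from compound 1 to compound 4 (beyond the scatter)). The earlier exchanges at this place stayed within the scatter, so the read-out is not insensitive to the group on this carbon, and compound 4 separates from the other three compounds. Nothing given here accounts for the rise.

On these data alone, the entering group differs from the leaving group in carrying oxygen instead of sulfur and a three-membered ring, and it remains open which of these goes with the step; an isopropoxy group or a cyclopropylmethylsulfanyl group on the carbonyl carbon would separate the two. As far as these compounds go, the read-out is taken at one concentration, so the potency of compound 4 also remains open.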